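This account rests on a few compounds, and the source may have more. Where it says the series, first, only, none or still open, it means among the compounds named here.

Compound 1, with the structure `Cn1ccc(-c2cccc3c2CCC3c2ncc[nH]2)n1`, is one of two compounds with a single number in a functional assay on CHO cells for agonist activity at Alpha-1A adrenergic receptor (Homo sapiens), read by FLIPR and calcium flux (a higher number here means a larger maximal response, a lower number a smaller maximal response), and it holds the lower place there: compound 1 gives 19%, while compound 2, with the structure `CCS(=O)(=O)Nc1cccc(Cc2c[nH]cn2)c1`, gives 96%, a gap beyond the usual scatter. Compound 3, with the structure `CS(=O)(=O)Nc1cccc2c1CCCC2c1ncc[nH]1`, has several entries in this assay, namely 47%; 79%; 79% (3 entries), and the several entries of compound 3 in this assay, 47%; 79%; 79% (3 entries) shows how far repeats of one compound can spread.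

Compound 4, with the structure `CNC(=O)c1cccc2c1CCC2c1ncc[nH]1`, has not yet been measured. It differs from compound 1 in one place: methylcarbamoyl in place of 1-methyl-1H-pyrazol-3-yl on an aromatic carbon, so a methylcarbamoyl group takes the place of the 1-methyl-1H-pyrazol-3-yl group on the shared core. No measured pair of compounds here carries that same change, so the size of the step can only be guessed from the compounds shown. Compound 4 is expected to respond more strongly than compound 1, with an estimated step of a number 36 percentage points higher from compound 1 to compound 4 (beyond the scatter) in this assay, since compound 3 gives 47%; 79%; 79% (3 entries) with a different small group on a closely related core. The estimate for compound 4 is therefore 55%, within a range from 25% to 85%.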

Compound 4, largest response reached (Emax), in percent of the reference or control that the assay uses: 59%
Estimate against measurement, compound 4: 4 percentage points below; the range from low to high includes it.
By their numbers in this assay, from the lowest: compound 1; then compound 4; then compound 2.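

In this assay, putting methylcarbamoyl on this aromatic carbon in place of 1-methyl-1H-pyrazol-3-yl gives a number 40 percentage points higher from compound 1 to compound 4 (beyond the scatter). Among these compounds, this is the first pair here that differs in one place only, so it shows that the group on this carbon alone can change the maximal response considerably, and that a ring in this group is not needed for the higher response. The size of this step still rests on single numbers for both compounds, and repeats of one compound can spread widely: the several entries of compound 3 in this assay, 47%; 79%; 79% (3 entries)

The change swaps the ring, the heavy-atom count and the hydrogen-bond donors and acceptors all at once, so this pair cannot show which of them matters. Going by these compounds, how a carboxylic acid, an amine or a longer chain on this same carbon would compare remains open.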